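This account rests on a few compounds, and the source may have more. Where it says the series, first, only, none or still open, it means among the compounds named here.

Compound 1 `Cc1cccc(-c2cc(NC(=O)c3ccc(C)cc3O)c[nH]c2=O)c1` gives 75000 nM in an ADME assay on HepG2 2.2.15 cells (Homo sapiens) for cytotoxicity, read by CCK-8 assay, with a stated time of 8 days; a higher number here means that more compound is tolerated, a lower number that less compound is tolerated.
Compound 2 `Cc1cccc(-c2cc(NC(=O)c3ccc(C(F)(F)F)cc3O)c[nH]c2=O)c1` gives 24200 nM in this assay.
Compound 3 `CCOc1ccc(-c2cc(NC(=O)c3ccc(C)cc3O)c[nH]c2=O)cc1` gives > 100000 nM in this assay, which is a limit of the assay and not a number; it sits at the limit of > 100000 nM in this assay, at which 1 of the 3 values shown sits.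

Compound 1 and compound 2 differ by one change, (trifluoromethyl in place of methyl on an aromatic carbon), and that change made a 3.1-fold lower number from compound 1 to compound 2 (0.49 log units; beyond the scatter). Compound 1 and compound 3 differ in the core, (4-ethoxyphenyl in place of 3-methylphenyl on an aromatic carbon), with an at least 1.3-fold higher number from compound 1 to compound 3 (0.12 log units; that floor lies within the scatter); since compound 3 gives only a limit, that step is a floor.

Compound 4 `CCOc1ccc(-c2cc(NC(=O)c3ccc(C(F)(F)F)cc3O)c[nH]c2=O)cc1` has not been measured in this assay. Within the data shown here, it differs from compound 3 by trifluoromethyl in place of methyl on an aromatic carbon, which is the same change, at the same place, as the one from compound 1 to compound 2.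

For compound 4 a step of about an at least 2.5-fold lower number from compound 3 to compound 4 (0.39 log units; beyond the scatter) is expected, a step of roughly the same size as the earlier one, because a 3.1-fold lower number from compound 1 to compound 2 (0.49 log units; beyond the scatter) showed what this change did on the core of compound 1. Since compound 3 gives only a limit, the starting point is uncertain, so the estimate for compound 4 is 40000 nM, expected between 15000 nM and 120000 nM.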

Compound 4, half-maximal cytotoxic concentration: 22200 nM
Compound 4: middle estimate off by 1.8-fold (0.26 log units), on the high side; measured number inside the range.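

In this assay, trifluoromethyl in place of methyl again goes with a lower number on the second core, with an at least 4.5-fold lower number from compound 3 to compound 4 (0.65 log units; beyond the scatter), so the direction of the change carried over in the two pairs shown. Compound 3 gives a limit of the assay and not a number, so whether the step has the same size on both cores cannot be settled: the same change on two cores in this assay, a 3.1-fold lower number (0.49 log units; beyond the scatter) from compound 1 to compound 2 and an at least 4.5-fold lower number (0.65 log units; beyond the scatter) from compound 3 to compound 4; the limit leaves it open whether they differ. Once trifluoromethyl is present, 4-ethoxyphenyl in place of 3-methylphenyl gives a 1.1-fold lower number from compound 2 to compound 4 (0.04 log units; within the scatter), so compound 2 and compound 4 cannot be told apart in this read-out, and no effect of that swap can be read from either pair: the same change on two cores in this assay, an at least 1.3-fold higher number (0.12 log units; that floor lies within the scatter) from compound 1 to compound 3 and a 1.1-fold lower number (0.04 log units; within the scatter) from compound 2 to compound 4; the limit leaves it open whether they differ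

The compounds shown hold only methyl or trifluoromethyl at this place, and only 3-methylphenyl or 4-ethoxyphenyl at the other. On these data alone, whether a chlorine, a nitrile or a longer chain at the first place, or an amine or a carboxylic acid on the second group, would go with a similar number remains open.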